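The source may hold more compounds than are shown below. What is called first, only, known or untested is meant among the compounds shown, and "the series" means these compounds.

Compounds measured so far:
compound 1, `COc1ccc(-n2nc(Sc3ccc(Cl)cc3)cc(CC[C@@H](C)NC(=O)[C@H]3CNC[C@@H]3c3ccccc3F)c2=O)cc1`, in a functional assay with Melanocortin receptor 4 (Homo sapiens) as the target, read by cAMP accumulation (on this read-out lower numbers stand for an effect already at smaller amounts and higher numbers for an effect only at larger amounts of compound), giving 710 nM
compound 2, `COc1ccc(-n2nc(Sc3ccc(Cl)cc3)cc(CC[C@@H](C)NC(=O)[C@H]3CNC[C@@H]3c3ccc(F)cc3)c2=O)cc1`, giving 110 nM
compound 3, `COc1ccc(-n2nc(Sc3ccc(Cl)cc3)cc(CC[C@@H](C)NC(=O)[C@H]3CNC[C@@H]3c3ccc(C)cc3)c2=O)cc1`, giving 750 nM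

Compound 3 carries the highest of the three numbers; its nearest neighbour is compound 1, a step of a 1.1-fold higher number from compound 1 to compound 3 (0.02 log units; within the scatter) away, while compound 2 lies further off, at a 6.8-fold higher number from compound 2 to compound 3 (0.83 log units; beyond the scatter). Compound 4, `COc1ccc([C@H]2CNC[C@@H]2C(=O)N[C@H](C)CCc2cc(Sc3ccc(Cl)cc3)nn(-c3ccc(OC)cc3)c2=O)cc1`, is not yet measured. It differs from compound 3 by methoxy in place of methyl on an aromatic carbon, so that the 4-methylphenyl on the saturated ring carbon becomes 4-methoxyphenyl. Among the measured compounds shown here, no measured step exchanges methyl for methoxy; the one step that touches this same aromatic carbon is a 6.8-fold higher number from compound 2 to compound 3 (0.83 log units; beyond the scatter), which shows that the group sitting para to the large group can shift the number clearly. The steps of a 6.5-fold lower number from compound 1 to compound 2 (0.81 log units; beyond the scatter) and a 1.1-fold higher number from compound 1 to compound 3 (0.02 log units; within the scatter) concern where the fluoro or methyl sits rather than what it is, and bear only loosely on this exchange. For the measured compounds named here, with no close precedent, the step to compound 4 is expected to be small, a 1.3-fold lower number from compound 3 to compound 4 (0.10 log units; within the scatter), with wide uncertainty. Compound 4 is therefore estimated at 600 nM, in a range from 200 nM to 1800 nM.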

Compound 4, half-maximal effective concentration: 430 nM
For compound 4 the middle estimate is 1.4-fold (0.14 log units) above the measured one, and the stated range covers the measured number.
By their numbers in this assay, from the lowest: compound 2; then compounds 4, 1 and 3 (each within the scatter of the next).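

In this assay, methoxy in place of methyl on this aromatic carbon gives a 1.7-fold lower number from compound 3 to compound 4 (0.24 log units; within the scatter), so the two groups are not told apart here. Methoxy does not match fluoro at this carbon, with a 3.9-fold higher number from compound 2 to compound 4 (0.59 log units; beyond the scatter), and the 4-methoxyphenyl group is not told apart from the 2-fluorophenyl group, with a 1.7-fold lower number from compound 1 to compound 4 (0.22 log units; within the scatter), which leaves the 4-fluorophenyl group of compound 2 alone in standing clear of the other three. No measurement at hand accounts for this difference.

The compounds shown leave open whether any other group on this carbon, such as chloro, hydroxy, nitrile or an amine, would reach the number of compound 2. They also leave open whether a longer ether such as ethoxy would stay with methoxy and methyl.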